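Swapping thiophene for benzofuran on a shared core

The compounds below may be only part of what the source reports. "The series", "measured", "known", "first", "only" and "open" are said of these compounds alone.

Compound 1 `COc1ncnc2c1c(-c1cccs1)cn2[C@@H]1O[C@H](CO)[C@@H](O)[C@H]1O`: in a functional assay on K562 cells (Homo sapiens), read by MTT assay, with a stated time of 72 h (on this read-out lower numbers stand for stronger inhibition and higher numbers for weaker inhibition), compound 1 gives 70 nM.
Compound 2 `CNc1ncnc2c1c(-c1cccs1)cn2[C@@H]1O[C@H](CO)[C@@H](O)[C@H]1O`: in this assay compound 2 reaches only a limit, > 20000 nM.
Compound 3 `CN(C)c1ncnc2c1c(-c1cccs1)cn2[C@@H]1O[C@H](CO)[C@@H](O)[C@H]1O`: in this assay compound 3 reaches only a limit, > 20000 nM.

Compound 1 is the only one of the three with a true number; the two others sit at the limit of the assay (the limit of > 20000 nM in this assay, at which 2 of the 3 values shown sit). The measured steps all concern the methoxy group on the shared core: an at least 280-fold higher number from compound 1 to compound 2 (2.45 log units; beyond the scatter) and an at least 280-fold higher number from compound 1 to compound 3 (2.45 log units; beyond the scatter), both large, while a step that the two limits leave unreadable from compound 2 to compound 3 cannot be read. Compound 4 `COc1ncnc2c1c(-c1cc3ccccc3o1)cn2[C@@H]1O[C@H](CO)[C@@H](O)[C@H]1O` keeps the methoxy of compound 1 unchanged; its one difference is 1-benzofuran-2-yl in place of thiophen-2-yl on an aromatic carbon. For the measured compounds named here, no measured step touches that five-membered ring group, so none of the three measured steps bears directly on this change, and there is no measured guide for its size or direction. With the methoxy kept, a modest step is expected, possibly within the scatter, in either direction. For compound 4 an estimate of 100 nM is given, in a range from 20 nM to 800 nM. This estimate means an expected step of a 1.4-fold higher number from compound 1 to compound 4 (0.15 log units; within the scatter).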

Compound 4, half-maximal inhibitory concentration: 20900 nM
Beside the measured number, compound 4's estimate is 210-fold (2.32 log units) below it; the whole stated range lies below it.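

The earlier compounds shown here varied only the methoxy group, while thiophen-2-yl stayed in place on the aromatic carbon of the five-membered ring, so they said nothing about how much that second place matters. With the methoxy kept, putting 1-benzofuran-2-yl there in this assay gives a 300-fold higher number from compound 1 to compound 4 (2.48 log units; beyond the scatter), which shows that good inhibition in this series depends on the thiophen-2-yl group as well as on the methoxy. Compound 4 does have a true number, but it lies close to the top of the range reached in this assay: the limit of > 20000 nM in this assay, at which 2 of the 4 values shown sit.

The change does two things at once, as it adds a six-membered aromatic ring of carbon only and puts oxygen in place of sulfur in the five-membered ring, and the compounds shown cannot tell which of these accounts for the loss. A furan-2-yl group, which has the oxygen without the added ring, and a 1-benzothiophen-2-yl group, which has the added ring with the sulfur kept, would separate the two parts, while a plain phenyl group would test whether a five-membered ring is needed here at all.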